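A few compounds are considered here, and "the series" means these few. Any claim that something is new, unique, unknown or untested is made for them only; others in the source may bear on it.

Compound 1, `CCOC(=O)c1cc2ccc(OCCCn3cc(CNC(=O)CCCCC4CCSS4)nn3)cc2oc1=O`, gives 28.3% in a functional assay on PC-12 cells (Rattus norvegicus) for cytotoxicity, read by MTT assay, with stated times of 3 h and 2 h, tested at 1 uM; on this read-out lower numbers stand for a weaker effect and higher numbers for a stronger effect at the one concentration tested.
Compound 2, `O=C(CCCCC1CCSS1)NCc1cn(CCCOc2ccc3cc(-c4ccccc4)c(=O)oc3c2)nn1`, gives 31.9% in this assay.
Compound 3, `CCOC(=O)c1cc2ccc(OCCCCCn3cc(CNC(=O)CCCCC4CCSS4)nn3)cc2oc1=O`, gives 35.1% in this assay.

All three carry the same dithiolane-bearing amide and triazole tail; compound 1 and compound 2 differ in one place only, (phenyl in place of ethoxycarbonyl on an aromatic carbon), and that change gave a number 3.6 percentage points higher from compound 1 to compound 2 (within the scatter). Compound 3 has a longer linker than compound 1, but the difference between the two cores is not broken down here. Compound 4, `O=C(CCCCC1CCSS1)NCc1cn(CCCCCOc2ccc3cc(-c4ccccc4)c(=O)oc3c2)nn1`, has not yet been measured in this assay. It differs from compound 3 by phenyl in place of ethoxycarbonyl on an aromatic carbon, the same change as before, made at an identically described place. The expected step, a number 3.6 percentage points higher from compound 3 to compound 4 (within the scatter), is about the size of the earlier one, because a number 3.6 percentage points higher from compound 1 to compound 2 (within the scatter) shows how this change behaved once. Compound 4 is therefore estimated to give about 38.7% in this assay, somewhere between 29% and 49%.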

Compound 4, a percentage reported as activity, at one concentration (the size of the read-out at that concentration, not a potency): 30.7%
Compound 4: middle estimate off by 8 percentage points, on the high side; the measured number falls inside the stated range.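

In this assay, phenyl in place of ethoxycarbonyl gave a number 4.4 percentage points lower from compound 3 to compound 4 (within the scatter). Set beside the earlier case, this step does not differ from it by more than repeated measurements would: the same change on two cores in this assay, a number 3.6 percentage points higher (within the scatter) from compound 1 to compound 2 and a number 4.4 percentage points lower (within the scatter) from compound 3 to compound 4, 8 percentage points apart, within the scatter of two such steps. On these two cores, then, the change carries across only in the sense that neither step stands out from the scatter, which shows neither a reliable direction nor a general absence of effect at other cores or concentrations.

The compounds shown leave open how a carboxylic acid or an amine would behave on this aromatic carbon. They also leave open whether the picture would hold with a longer chain joining the core to the triazole.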